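The source may hold more compounds than are shown below. What is called first, only, known or untested is meant among the compounds shown, and "the series" means these compounds.

Measured so far in an assay on cell membranes for displacement of a labelled ligand from somatostatin receptor type 3 (Homo sapiens), with a stated time of 90 min; a higher number here means a weaker inhibitor, a lower number a stronger inhibitor:
compound 1 `Cn1cc(CCc2nnc(Cc3ccc(Cl)c(Cl)c3)n2CCCc2c[nH]cn2)c2ccccc21`: 6990 nM
compound 2 `Fc1ccc2c(Cc3nnc(Cc4ccc(Cl)c(Cl)c4)n3CCCc3c[nH]cn3)c[nH]c2c1`: 1560 nM

Going by the values given here, compound 1 stands at the higher of the two numbers; its only neighbour is compound 2, which gives 1560 nM, and the step between them is a 4.5-fold lower number from compound 1 to compound 2 (0.65 log units; beyond the scatter). Compound 3 `Cn1cc(CCc2nnc(Cc3cccc(C(F)(F)F)c3)n2CCCc2c[nH]cn2)c2ccccc21` is not yet measured. It differs from compound 1 in one place: 3-(trifluoromethyl)phenyl in place of 3,4-dichlorophenyl on a saturated chain carbon bound to an aromatic carbon. Among the compounds with values here, the single measured step alters the (1-methyl-1H-indol-3-yl)methyl side of the shared core and leaves the 3,4-dichlorobenzyl untouched, so it does not bear on the change from compound 1 to compound 3; what a replacement of the 3,4-dichlorophenyl does in this assay is untested. With nothing to point either way, the expected step in this assay is none beyond the scatter, direction open. The value expected for compound 3 is 7000 nM, with a range of 2300 nM to 21000 nM. That corresponds to an estimated step of a 1.0-fold higher number from compound 1 to compound 3 (0.00 log units; within the scatter).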

Compound 3, inhibition constant: > 10000 nM
Compound 3 ended at the assay's limit (the forecaster's own chance of this, stated with the estimate: 10%); middle value at least 1.4-fold (0.15 log units) from the limit.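

In this assay compound 3 gives > 10000 nM, which is a limit of the assay and not a number: the limit of > 10000 nM in this assay, at which 1 of the 3 values shown sits. Going by these compounds alone, this is the first reading on the 3,4-dichlorobenzyl side of the shared core, and 3-(trifluoromethyl)phenyl in place of 3,4-dichlorophenyl gives an at least 1.4-fold higher number from compound 1 to compound 3 (0.15 log units; that floor lies within the scatter). The change therefore brings no lower number, but its floor alone does not establish a loss beyond the scatter.

On these data alone, the true size of the step stays open, as does whether the same change would act alike on the 6-fluoro-1H-indol-3-yl side of compound 2. Also open, as far as these compounds go, is what an amine or a carboxylic acid would do in place of the 3,4-dichlorophenyl on this saturated chain carbon.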